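The compounds below may be only part of what the source reports. "The series", "measured", "known", "first", "only" and "open" are said of these compounds alone.

Within the data shown here, compound 2 `Cc1n[nH]c2ccc(-c3nc4cnc(N5CCN(C)CC5)cn4c3Nc3ccc(F)cc3Br)cc12` gives 82.4% in a functional assay on MV4-11 cells (Homo sapiens) for inhibition, with a stated time of 120 h, tested at 10 uM (on this read-out lower numbers stand for less inhibition and higher numbers for more inhibition at the one concentration tested (going by the name of the read-out)), the higher of the two numbers so far; the other, compound 1 `Cc1n[nH]c2ccc(-c3nc4cnc(N5CCN(C)CC5)cn4c3Nc3cccc(F)c3)cc12`, gives 18.5% in this assay. The change to compound 3 `Cc1n[nH]c2ccc(-c3nc4cnc(N5CCN(C)CC5)cn4c3Nc3ccc(F)c(Cl)c3)cc12` is 3-chloro-4-fluorophenyl in place of 2-bromo-4-fluorophenyl on a nitrogen on an aromatic ring. Among the measured compounds shown here, the only measured step, a number 63.9 percentage points higher from compound 1 to compound 2 (beyond the scatter), shows that changing the halogen pattern on this phenyl ring can move inhibition greatly, and compound 3 shares part of each neighbour's pattern. A downward step from compound 2 is therefore expected, of about a number 32.4 percentage points lower from compound 2 to compound 3 (beyond the scatter), though with much uncertainty. Compound 3 is estimated at 50%, between 15% and 85%.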

Compound 3, a percentage reported as inhibition, at one concentration (the size of the read-out at that concentration, not a potency): 84.1%
For compound 3 the middle estimate is 34.1 percentage points below the measured one, within the range that was stated.
By their numbers in this assay, from the lowest: compound 1; then compounds 2 and 3 (each within the scatter of the next).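

In this assay the swap to 3-chloro-4-fluorophenyl gives a number 1.7 percentage points higher from compound 2 to compound 3 (within the scatter), so the bromine-bearing ring of compound 2 is not the only halogen pattern at this position that reaches this level. The same ring gives a number 65.6 percentage points higher from compound 1 to compound 3 (beyond the scatter), which places both rings carrying two halogens far above the 3-fluorophenyl ring of compound 1. Nothing available explains these differences.

As far as these compounds go, it remains open whether 4-fluorophenyl alone would hold this level. From the compounds shown here alone, it also remains open whether a methoxy group or a nitrile could stand in place of the chlorine.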